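The source may report more compounds than this note shows. Statements on the series, on what has been measured and on what is new or still open speak of the compounds shown alone.

Compound 1, `Cn1c(-c2cccc(C#N)c2)cnc1NC(=O)c1ccc(F)cc1`, in a toxicity assay on THP-1 cells (Homo sapiens) for inhibition (a higher number here means that more compound is tolerated, a lower number that less compound is tolerated), gives > 100000 nM, which is a limit of the assay and not a number.
Compound 2, `Cn1c(-c2cccc(C#N)c2)cnc1NC(=O)c1ncc[nH]1`, in this assay gives > 50000 nM, again a limit rather than a number.
Compound 3, `Cc1ccccc1C(=O)Nc1ncc(-c2ccccc2)n1C`, in this assay gives > 100000 nM, once more a limit.

Compound 1 thus stands at a limit in this assay, and so do both other values shown: two of the three sit at the limit of > 100000 nM in this assay, at which 2 of the 3 values shown sit, and one at the limit of > 50000 nM in this assay, at which 1 of the 3 values shown sits. Among the compounds with values here, the only step measured between two compounds that differ in one place, a step that the two limits leave unreadable from compound 1 to compound 2, puts 1H-imidazol-2-yl in place of 4-fluorophenyl on a carbonyl carbon, and its size cannot be read because a step that the two limits leave unreadable from compound 1 to compound 2 runs between two limits.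

Compound 4, `Cn1c(-c2ccc(Br)cc2)cnc1NC(=O)c1ccc(F)cc1`, differs from compound 1 by 4-bromophenyl in place of 3-cyanophenyl on an aromatic carbon. Within the data shown here, no measured step touches this change, and the one measured step is unreadable, so nothing in the set points to a rise or a fall beyond the scatter. Compound 1 tolerates the compound up to its limit, and compound 4 is expected to do the same, so the step that the limit leaves unreadable from compound 1 to compound 4 is expected to be none beyond the scatter. For compound 4 the estimate in this assay is 150000 nM, with a range from 50000 nM to 500000 nM, most likely reported again as a limit.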

Compound 4, half-maximal cytotoxic concentration: 46000 nM
For compound 4 the middle estimate is 3.3-fold (0.51 log units) above the measured one; the whole stated range lies above it.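

Within the data shown here, putting 4-bromophenyl in place of 3-cyanophenyl on this aromatic carbon gives an at least 2.1-fold lower number from compound 1 to compound 4 (0.33 log units; beyond the scatter) in this assay, so a change at this position of the five-membered aromatic ring can move the read-out, which no readable step among the earlier compounds could show. Compound 1 stands at a limit, > 100000 nM, so the printed step is a minimum and its full size stays unknown, and this limit is shared: the limit of > 100000 nM in this assay, at which 2 of the 4 values shown sit.
Compound 4 alone gives a number rather than a limit, and nothing shown tells which part of the exchange of 3-cyanophenyl for 4-bromophenyl accounts for the lower value.

Going by these compounds, it remains open whether the lower number follows the bromine itself or would also appear with a chlorine, an amine or a carboxylic acid on the phenyl ring at this position. On these data alone, it is equally open whether the same exchange would lower the number when 1H-imidazol-2-yl, as in compound 2, sits on the carbonyl carbon in place of 4-fluorophenyl.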